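Ring stereocentre inversion from compound 2 to compound 3

The compounds below may be only part of what the source reports. "The series", "measured", "known", "first", "only" and "open" are said of these compounds alone.

Going by the values given here, compound 2 `N[C@H](C(=O)O)[C@H]1CC(O)=NO1` holds the only number: in a functional assay on CHO cells with metabotropic glutamate receptor 1 (Rattus norvegicus) as the target, read by cAMP accumulation (on this read-out higher numbers stand for an effect only at larger amounts of compound and lower numbers for an effect already at smaller amounts), compound 2 gives 82000 nM. Compound 1 `N[C@@H](C(=O)O)[C@H]1CC(O)=NO1` reaches only a limit of the assay in this assay, at > 1000000 nM. Among the compounds with values here, the one measured step is an at least 12-fold lower number from compound 1 to compound 2 (1.08 log units; beyond the scatter); it rests on the limit of > 1000000 nM in this assay, at which 1 of the 2 values shown sits, and on (the fact that compounds 1 and 2 differ only in the configuration as drawn).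

Compound 3 `N[C@H](C(=O)O)[C@@H]1CC(O)=NO1` is not yet measured in this assay. The change from compound 2: the two compounds have the same atoms and bonds and differ only in configuration as drawn: 1 of 2 stereo elements differ; a stereocentre at a saturated ring carbon is drawn R in compound 2 and S in compound 3. Within the data shown here, no measured step touches the ring stereocentre; the single measured step, an at least 12-fold lower number from compound 1 to compound 2 (1.08 log units; beyond the scatter), concerns the chain stereocentre and was large, so a step beyond the scatter is considered likely for the ring inversion as well, while the direction cannot be read from the data. The step is estimated as a 3.0-fold higher number from compound 2 to compound 3 (0.48 log units; beyond the scatter), taken towards a weaker effect with wide uncertainty. Compound 3 is expected to give 250000 nM, with a range from 30000 nM to 1000000 nM.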

Compound 3, half-maximal effective concentration: 610000 nM
Compound 3: middle estimate off by 2.4-fold (0.39 log units), on the low side, within the range that was stated.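

In this assay, the ring stereocentre also carries a step beyond the scatter, a 7.4-fold higher number from compound 2 to compound 3 (0.87 log units; beyond the scatter), with no atom or bond changed. Each of the two stereocentres now has a measured step. The chain step is an at least 12-fold lower number from compound 1 to compound 2 (1.08 log units; beyond the scatter), and it rests on a limit. Compound 2 keeps the lowest number of the three compounds. The new step can be assigned only to the ring configuration: the fact that compounds 2 and 3 differ only in the configuration as drawn

With both stereocentres changed, the data give an at least 1.6-fold lower number from compound 1 to compound 3 (0.21 log units; that floor lies within the scatter). Compound 1 stands at a limit, and this step cannot be assigned to either stereocentre. Open, as far as these compounds go, is how the stereoisomer with the chain stereocentre drawn R and the ring stereocentre drawn S would read, and how a carboxamide in place of the carboxylic acid would read on the configuration of compound 2.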